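A few compounds are considered here, and "the series" means these few. Any claim that something is new, unique, unknown or untested is made for them only; others in the source may bear on it.

Measured so far:
compound 1, `Cc1nc(S(C)(=O)=O)ccc1Oc1ncnc(OC2CCN(C(=O)OC(C)C)CC2)c1F`: in a functional assay on isolated protein for inhibition of Glucose-dependent insulinotropic receptor (Homo sapiens), read by HTRF and cAMP accumulation (on this read-out higher numbers stand for an effect only at larger amounts of compound and lower numbers for an effect already at smaller amounts), compound 1 gives 21 nM
compound 2, `Cc1nc(S(C)(=O)=O)ccc1Oc1ncnc(OC2CCN(C(=O)SC(C)C)CC2)c1F`: in this assay compound 2 gives 6.8 nM

Among the measured compounds shown here, compound 2 stands at the lowest of the two numbers; the one recorded step is a 3.1-fold lower number from compound 1 to compound 2 (0.49 log units; beyond the scatter), where isopropylsulfanyl replaced isopropoxy on the carbonyl carbon. Compound 3, `CCC(F)(F)C(=O)N1CCC(Oc2ncnc(Oc3ccc(S(C)(=O)=O)nc3C)c2F)CC1`, is not yet measured in this assay. It differs from compound 2 as follows: 1,1-difluoropropyl in place of isopropylsulfanyl on a carbonyl carbon. For the measured compounds named here, no measured step bears directly on this change. Going by the values given here, the only step recorded, from compound 1 to compound 2, was modest and concerned the same carbonyl carbon, which suggests that substituents at this position have shifted the number by limited amounts so far, though the present change is of another kind. The expectation for compound 3 is a number between those of compound 1 and compound 2, giving a 2.2-fold higher number from compound 2 to compound 3 (0.34 log units; beyond the scatter) with wide uncertainty. The estimate for compound 3 is 15 nM, range 4 nM to 55 nM.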

Compound 3, half-maximal effective concentration: 17.4 nM
For compound 3 the middle estimate is 1.2-fold (0.06 log units) below the measured one, and the stated range covers the measured number.
By their numbers in this assay, from the lowest: compound 2; then compounds 3 and 1 (each within the scatter of the next).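

At the carbonyl carbon, isopropylsulfanyl stays ahead of a second replacement, with a 2.6-fold higher number from compound 2 to compound 3 (0.41 log units; beyond the scatter) when 1,1-difluoropropyl enters in this assay. Against isopropoxy, the same entering group gives a 1.2-fold lower number from compound 1 to compound 3 (0.08 log units; within the scatter) and thus no readable difference, and among these three compounds only isopropylsulfanyl stands apart. Nothing available on these compounds accounts for either step.

Open, as far as these compounds go, is whether the lower number of compound 2 belongs to the sulfur atom or to the whole isopropylsulfanyl group, and a sulfanyl group with a different carbon chain would separate the two. Also open, from the compounds shown here alone, is what the fluorine atoms of compound 3 contribute, which a plain propyl chain or an amine on the same carbonyl carbon would begin to test.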